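Isopropyl carbamoyl on the chloro-substituted piperazine dithiocarbamate

A few compounds are considered here, and "the series" means these few. Any claim that something is new, unique, unknown or untested is made for them only; others in the source may bear on it.

Compound 1 `CC(C)NC(=O)N1CCN(C(=S)SCc2cn(Cc3ccc(F)cc3)nn2)CC1`: 760 nM
Compound 2 `NC(=O)N1CCN(C(=S)SCc2cn(Cc3ccc(Cl)cc3)nn2)CC1`: > 128000 nM
Compound 3 `CCNC(=O)N1CCN(C(=S)SCc2cn(Cc3ccc(Cl)cc3)nn2)CC1`: 35400 nM

In a functional assay on MGC-803 cells (Homo sapiens) for cytotoxicity, read by MTT assay, with a stated time of 72 h (on this read-out lower numbers stand for stronger inhibition and higher numbers for weaker inhibition), compound 3 gives 35400 nM, the higher of the two numbers reported; the nearest number is that of compound 1, which gives 760 nM. The value of compound 2 is a limit of the assay, not a number. For the measured compounds named here, the one step among the measured compounds, an at least 3.6-fold lower number from compound 2 to compound 3 (0.55 log units; beyond the scatter), turned a limit of > 128000 nM in this assay, at which 1 of the 3 values shown sits, into a number. Compound 4 `CC(C)NC(=O)N1CCN(C(=S)SCc2cn(Cc3ccc(Cl)cc3)nn2)CC1` differs from compound 3 in one place: methyl in place of hydrogen on a saturated chain carbon bound to an amide-type nitrogen and a saturated chain carbon. This is the same direction of growth on the amide-type nitrogen as in the step from compound 2 to compound 3, and compound 1, which carries the isopropylcarbamoyl group, gives 760 nM. A further drop of the number is therefore expected in this assay, and compound 4 is estimated to reach 1500 nM, within 400 nM to 8000 nM, a step of a 24-fold lower number from compound 3 to compound 4 (1.37 log units; beyond the scatter).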

Compound 4, half-maximal inhibitory concentration: 19900 nM
The estimate for compound 4 lay 13-fold (1.12 log units) below the measured number, and the stated range ends below it.
By their numbers in this assay, from the lowest: compound 1; then compounds 4 and 3 (each within the scatter of the next). At a limit, above all of these: compound 2.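

In this assay, going from ethylcarbamoyl to isopropylcarbamoyl adds one methyl on a saturated chain carbon bound to an amide-type nitrogen, and this gives no change that can be told from the scatter: a 1.8-fold lower number from compound 3 to compound 4 (0.25 log units; within the scatter). The step that brings in the whole isopropyl group gives an at least 6.4-fold lower number from compound 2 to compound 4 (0.80 log units; beyond the scatter), while with isopropylcarbamoyl held in common, chloro in place of fluoro on an aromatic carbon gives a 26-fold higher number from compound 1 to compound 4 (1.42 log units; beyond the scatter), so among these compounds the large step goes with the halogen, not with the chain. Compound 2 stands at a limit of the assay, not at a number: the limit of > 128000 nM in this assay, at which 1 of the 4 values shown sits.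

Going by these compounds, whether a longer chain, a cyclohexyl group or a chain ending in an amine on the amide-type nitrogen would shift the reading remains open. So does the effect of bromo or methoxy in place of chloro on the aromatic carbon.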